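Hexyloxy to propargyloxy on the shared core

The source may hold more compounds than are shown below. What is called first, only, known or untested is meant among the compounds shown, and "the series" means these compounds.

In a functional assay on aorta (Rattus norvegicus, strain Sprague-Dawley) for inhibition (a lower number here means that less compound is needed, a higher number that more compound is needed for the effect), compound 1 `Cc1cc2c(c3c1C[C@@H]1[C@@H](C)CO[C@]1(C)O3)C[C@@H]1[C@@H](C)CO[C@]1(C)O2` gives 52000 nM. Compound 2 `CCCCCCOc1cc2c(c3c1C[C@@H]1[C@@H](C)CO[C@]1(C)O3)C[C@@H]1[C@@H](C)CO[C@]1(C)O2` stands at > 200000 nM, which is a limit of the assay and not a number. Compound 3 `C#CCOc1cc2c(c3c1C[C@@H]1[C@@H](C)CO[C@]1(C)O3)C[C@@H]1[C@@H](C)CO[C@]1(C)O2` differs from it by ethynyl in place of pentyl on a saturated chain carbon bound to an oxygen on an aromatic ring, that is, hexyloxy to propargyloxy. Among the compounds with values here, the one measured step bearing on this, an at least 3.8-fold higher number from compound 1 to compound 2 (0.58 log units; beyond the scatter), for hexyloxy in place of methyl on an aromatic carbon, suggests a modest move to a lower number in this assay. The expected step is an at least 2.2-fold lower number from compound 2 to compound 3 (0.34 log units; beyond the scatter). Compound 3 is estimated at 90000 nM, within a range of 30000 nM to 200000 nM.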

Compound 3, half-maximal effective concentration: 22000 nM
Estimate against measurement, compound 3: 4.1-fold (0.61 log units) above; measured number below the stated range.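

In this assay, a group on the oxygen at the aromatic carbon does not have to raise the number: ethynyl in place of pentyl gives an at least 9.0-fold lower number from compound 2 to compound 3 (0.95 log units; beyond the scatter). On these data alone, compound 2 carries a limit of the assay and not a number, so the full size of that step stays unknown: the limit of > 200000 nM in this assay, at which 1 of the 3 values shown sits. Measured against the methyl group, the propargyloxy group also gives a 2.4-fold lower number from compound 1 to compound 3 (0.37 log units; beyond the scatter), reversing the direction seen with hexyloxy.

Chain length and the triple bond change together here, so their contributions cannot be separated. A propyloxy chain, or an amine at the chain end, would be needed to address this.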